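Shifting the chlorine on the anilide ring of compound 1

This account rests on a few compounds, and the source may have more. Where it says the series, first, only, none or still open, it means among the compounds named here.

Measured compounds:
- compound 1, `CCCCCCNC(=O)Oc1ccc(Cl)cc1C(=O)Nc1cccc(Cl)c1`: 5.53
- compound 2, `CCCCCCCCCCNC(=O)Oc1ccc(Cl)cc1C(=O)Nc1cccc(Cl)c1`: 7.19

Both compounds share one core and differ only in the chain on the carbamate nitrogen. In a physicochemical assay for lipophilicity (on this read-out lower numbers stand for lower lipophilicity and higher numbers for higher lipophilicity), compound 1 gives 5.53, and compound 2 gives 7.19. Compound 1 therefore stands lowest of the two numbers, with the measured step of a number 1.66 log units higher from compound 1 to compound 2 (beyond the scatter) separating them, a step well beyond the scatter.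

Compound 3, `CCCCCCNC(=O)Oc1ccc(Cl)cc1C(=O)Nc1ccc(Cl)cc1`, has not yet been measured in this assay. It keeps the hexyl chain of compound 1 and changes only the anilide ring: 4-chlorophenyl in place of 3-chlorophenyl on an amide-type nitrogen. Among the measured compounds shown here, no measured step touches this part of the molecule; the only step known, a number 1.66 log units higher from compound 1 to compound 2 (beyond the scatter), concerns the chain and says nothing about moving a chlorine from one ring position to another. The atoms are the same in both compounds, so no step beyond the scatter is expected in this assay in either direction. For compound 3 the expected value is 5.6, with a range from 5.3 to 5.9. This expectation amounts to a step of a number 0.07 log units higher from compound 1 to compound 3 (within the scatter), which is within the scatter.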

Compound 3, partition coefficient: 5.53
Compound 3: middle estimate off by 0.07 log units, on the high side; measured number inside the range.
By their numbers in this assay, from the lowest: compounds 1 and 3 (each within the scatter of the next); then compound 2.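

Among the compounds shown here, until now the only measured change was in the chain on the carbamate nitrogen, so nothing was known about the anilide ring; this result provides the first reading there. In this assay, placing 4-chlorophenyl in place of 3-chlorophenyl on an amide-type nitrogen gives no change at the digits printed from compound 1 to compound 3 (within the scatter), while the change in the chain gave a number 1.66 log units higher from compound 1 to compound 2 (beyond the scatter), so for this pair, rearranging the same atoms on the ring leaves the read-out flat, whereas adding carbons to the chain moved it well beyond the scatter. No supporting measurement is available to explain why the two chlorine placements read alike, and this single pair cannot show whether the same would hold on any other version of the core.

The compounds shown leave open whether the chlorine move would read the same when combined with the longer chain of compound 2, where the number is already much higher. They also leave open what this ring position would tolerate if a different group, such as an amine or a carboxylic acid, took the place of the chlorine, since only chlorine has been compared here.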